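Benzyl for Cyclopropyl on the Ring Nitrogen

The compounds below may be only part of what the source reports. "The series", "measured", "known", "first", "only" and "open" are said of these compounds alone.

Compound 1 `COc1ccc(C(C)=O)cc1CSc1nc2cc(NC(=O)C3CC3)ccc2n1C(C)C`: > 10000 nM
Compound 2 `COc1ccc([N+](=O)[O-])cc1CSc1nc2cc(NC(=O)NC(C)(C)C)ccc2n1C1CC1`: 860 nM

Of the compounds shown here, two have been tested in an assay on isolated protein for inhibition of Gonadotropin-releasing hormone receptor (Rattus norvegicus); on this read-out higher numbers stand for weaker inhibition and lower numbers for stronger inhibition. Compound 1 gives > 10000 nM, which is a limit of the assay and not a number. Compound 2 gives 860 nM, the only number shown, so it stands as the one measured point to build from. One of the two values sits at a limit (the limit of > 10000 nM in this assay, at which 1 of the 2 values shown sits), which leaves little room to judge how wide this series spreads.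

Compound 3 `COc1ccc([N+](=O)[O-])cc1CSc1nc2cc(NC(=O)NC(C)(C)C)ccc2n1Cc1ccccc1` has not been measured. It differs from compound 2 in one place: benzyl in place of cyclopropyl on an aromatic nitrogen. Among the compounds with values here, nothing among the measured compounds tells how this assay responds to a change at that ring nitrogen, since no pair of measured compounds differs only there. The expectation is therefore a cautious one: a step from compound 2 to compound 3 of about a 1.7-fold higher number from compound 2 to compound 3 (0.24 log units; within the scatter), a small drift toward weaker inhibition that may well stay within the usual scatter. Compound 3 is estimated at 1500 nM, with a likely range from 300 nM to 8000 nM.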

Compound 3, half-maximal inhibitory concentration: 160 nM
Estimate against measurement, compound 3: 9.4-fold (0.97 log units) above; measured number below the stated range.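

Until this pair, nothing showed whether this assay responds to a change on the ring nitrogen, and replacing cyclopropyl with benzyl there gives clearly stronger inhibition (a 5.4-fold lower number from compound 2 to compound 3 (0.73 log units; beyond the scatter)). This shows that the position is not a silent one: what sits on this aromatic nitrogen matters, and the step goes toward stronger inhibition when the three-membered ring gives way to the larger benzyl with its six-membered aromatic ring. Nothing shown here accounts for the gain, so this single pair records the size and direction of the effect but not its cause.

A single step cannot separate the effect of the aromatic ring from that of the greater number of heavy atoms, so open questions remain about how a plain longer chain such as n-butyl, a phenethyl group with its extra carbon, or a chain ending in an amine would compare on this nitrogen. Compound 1 differs from the other two in more than one place and its value is a limit, so it cannot show whether the gain from benzyl would carry over to other groups elsewhere on the core.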